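A few compounds are considered here, and "the series" means these few. Any claim that something is new, unique, unknown or untested is made for them only; others in the source may bear on it.

For the measured compounds named here, in a functional assay on MCF7 cells (Homo sapiens) for inhibition, read by CCK-8 assay, with a stated time of 72 h (a lower number here means a stronger inhibitor, a higher number a weaker inhibitor), three close relatives have numbers so far: compound 1 `Cc1ccccc1NS(=O)(=O)c1cccc(CCCCCCNC(=O)/C=C/c2cccnc2)c1` gives 0.226 nM, compound 2 `Cc1ccc(C)c(NS(=O)(=O)c2cccc(CCCCCCNC(=O)/C=C/c3cccnc3)c2)c1` gives 0.6 nM, and compound 3 `O=C(/C=C/c1cccnc1)NCCCCCCc1cccc(S(=O)(=O)Nc2ccc(Cl)cc2)c1` gives 5.94 nM. Compound 3 has the highest number of the three, which makes it the weakest inhibitor of this small set.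

Compound 4 `O=C(/C=C/c1cccnc1)NCCCCCCc1cccc(S(=O)(=O)Nc2ccc(F)c(Cl)c2)c1` keeps the shared core and has 3-chloro-4-fluorophenyl in place of 4-chlorophenyl on a sulfonamide nitrogen. Going by the values given here, no measured step makes this exact change, so the guidance is indirect. Replacing the whole group on that nitrogen gave a large 26-fold higher number from compound 1 to compound 3 (1.42 log units; beyond the scatter) and a modest 9.9-fold higher number from compound 2 to compound 3 (1.00 log units; beyond the scatter). The smallest change measured, methyl in place of hydrogen on an aromatic carbon, still gave a modest 2.7-fold higher number from compound 1 to compound 2 (0.42 log units; beyond the scatter).

The change to compound 4 is also small, but nothing measured shows which way it should push the number. A small shift with no firm direction is therefore expected, most likely none beyond the scatter. The estimated step is a 1.2-fold lower number from compound 3 to compound 4 (0.07 log units; within the scatter). The expected value for compound 4 is 5 nM, within an estimated range of 1.5 nM to 17 nM.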

Compound 4, half-maximal inhibitory concentration: 6.3 nM
Estimate against measurement, compound 4: 1.3-fold (0.10 log units) below; the measured number falls inside the stated range.
By their numbers in this assay, from the lowest: compound 1; then compound 2; then compounds 3 and 4 (each within the scatter of the next).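

In this assay, the swap on the sulfonamide nitrogen gives a 1.1-fold higher number from compound 3 to compound 4 (0.03 log units; within the scatter) and lies within the scatter, so adding a fluorine and changing where the chlorine sits leaves no readable difference between these two halogen-bearing phenyl groups. For the compounds shown here, the gap to the methyl-bearing phenyl groups now holds for a second halogen-bearing group, with an 11-fold higher number from compound 2 to compound 4 (1.02 log units; beyond the scatter) and a 28-fold higher number from compound 1 to compound 4 (1.45 log units; beyond the scatter) both lying beyond the scatter, and no compound here goes against this. Nothing available explains why the methyl-bearing and halogen-bearing groups differ in this way.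

Still open, on these data alone, is whether a methoxy or an amino group on this phenyl ring would fall with the methyl-bearing compounds or the halogen-bearing ones. A single fluorine, with no chlorine, also remains to be placed.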